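This account rests on a few compounds, and the source may have more. Where it says the series, first, only, none or still open, it means among the compounds named here.

Measured compounds:
- compound 1 `CCOc1cc2[nH]c(Cc3nn(CC(=O)N4CCOCC4)c(=O)c4ccccc34)nc2cc1Cl`: 10 nM
- compound 2 `O=C(O)Cn1nc(Cc2nc3cc(Cl)c(OC(F)(F)F)cc3[nH]2)c2ccccc2c1=O`: 31 nM
- compound 3 `O=C(Cc1nn(C2CC2)c(=O)c2ccccc12)Nc1ccc(OC(F)(F)F)c(Cl)c1`: 218 nM

In a functional assay on CHO cells for antagonist activity at sphingosine 1-phosphate receptor 2 (Homo sapiens), read by calcium flux (on this read-out lower numbers stand for stronger inhibition and higher numbers for weaker inhibition), compound 2 gives 31 nM, which places it second highest of the three numbers: compound 1 gives a lower number, 10 nM, and compound 3 a higher one, 218 nM, both gaps lying beyond the usual scatter. Compound 4 `COc1cc2[nH]c(Cc3nn(CC(=O)O)c(=O)c4ccccc34)nc2cc1Cl` has not yet been measured in this assay. It differs from compound 2 in one place: methyl in place of trifluoromethyl on an oxygen on an aromatic ring, that is, trifluoromethoxy becomes methoxy. Within the data shown here, no measured pair in this set isolates that exchange, so there is no step to lean on. Since compound 1, whose oxygen carries an ethyl rather than a trifluoromethyl, gives 10 nM, a small alkyl on that oxygen is expected to be tolerated, and the step from compound 2 to compound 4 is expected to be a 1.2-fold lower number from compound 2 to compound 4 (0.09 log units; within the scatter), most likely within the scatter or a modest gain. Compound 4 is accordingly estimated at 25 nM, between 8 nM and 80 nM.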

Compound 4, half-maximal inhibitory concentration: 61 nM
Compound 4: middle estimate off by 2.4-fold (0.39 log units), on the low side; the measured number falls inside the stated range.
By their numbers in this assay, from the lowest: compound 1; then compounds 2 and 4 (each within the scatter of the next); then compound 3.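

In this assay, methyl in place of trifluoromethyl on an oxygen on an aromatic ring gives a 2.0-fold higher number from compound 2 to compound 4 (0.29 log units; within the scatter). Among these compounds, this is the first step in the set that isolates this position, and it shows that compound 2 and compound 4 cannot be told apart here, so the three fluorine atoms of the trifluoromethyl group are not needed for a number in this range. Nothing available explains this outcome at the level of the molecule.

Going by these compounds, what a difluoromethyl or a propyl on that oxygen would give remains open, as does the outcome of replacing the oxygen with an amine. On these data alone, it is also open whether the same exchange would read alike in a compound carrying the morpholine amide of compound 1 instead of the carboxylic acid.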